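Stereochemical inversion at one ring carbon in a cytotoxicity series

The source may hold more compounds than are shown below. What is called first, only, known or untested is meant among the compounds shown, and "the series" means these compounds.

Measured compounds in a functional assay on PC-12 cells (Rattus norvegicus) for cytotoxicity, read by MTT assay, with a stated time of 24 h; a lower number here means a stronger inhibitor, a higher number a weaker inhibitor:
compound 1 `CC(=O)O[C@@]1(C)CCC(=O)[C@@H](C)CCC[C@]2(C)O[C@H]2C(=O)C(=C(C)C)CC1` gives 24500 nM
compound 2 `CC(=O)O[C@]1(C)CCC(=C(C)C)C(=O)[C@@H]2O[C@@]2(C)C[C@H]2C[C@H](C)[C@@](O)(CC1)O2` gives 37100 nM
compound 3 `CC(=O)O[C@@]1(C)CCC/C(C)=C/CC[C@@]2(C)O[C@@H]2C(=O)C(=C(C)C)CC1` gives 47100 nM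

Compound 1 holds the lowest of the three numbers in this assay, yet its gaps to compound 2 and to compound 3 both fall within the usual scatter, so no ordering among the three can be claimed. Compound 4 `CC(=O)O[C@@]1(C)CCC(=O)[C@H](C)CCC[C@]2(C)O[C@H]2C(=O)C(=C(C)C)CC1` is the unmeasured compound: the two compounds have the same atoms and bonds and differ only in configuration as drawn: 1 of 4 stereo elements differ; a stereocentre at a saturated ring carbon is drawn S in compound 1 and R in compound 4. Going by the values given here, no step between measured compounds covers a change of this kind, so there is no precedent to lean on. With all three measured values this close, no shift beyond the scatter is expected in either direction. For compound 4 the estimate in this assay is 30000 nM, with a range from 12000 nM to 75000 nM. The expected step of a 1.2-fold higher number from compound 1 to compound 4 (0.09 log units; within the scatter) stays within the scatter.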

Compound 4, half-maximal inhibitory concentration: 43800 nM
Compound 4: the middle estimate sits 1.5-fold (0.16 log units) below what was measured, and the stated range covers the measured number.
By their numbers in this assay, from the lowest: compounds 1, 2, 4 and 3 (each within the scatter of the next).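

In this assay, going by these compounds alone, inversion at this saturated ring carbon gives a 1.8-fold higher number from compound 1 to compound 4 (0.25 log units; within the scatter), the first reading on this position, for which the earlier compounds offered no step. Configuration at this carbon, S or R as drawn, therefore has no effect beyond the scatter in this series. The pair isolates that single change: the fact that compounds 1 and 4 differ only in the configuration as drawn. Whether an amine or a carboxylic acid on the shared core would move the number beyond the scatter stays open, and the compounds shown give no reading on it.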